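Cytotoxicity notes: aryl amine replaces benzyl amine on shared core

A few compounds are considered here, and "the series" means these few. Any claim that something is new, unique, unknown or untested is made for them only; others in the source may bear on it.

Compound 3 `CN1CCN(c2ccc(Nc3ncc(Cl)c(NCc4ccc(C(F)(F)F)cc4)n3)nc2)CC1` gives 26200 nM in an ADME assay on L02 cells (Homo sapiens) for inhibition, read by CCK-8 assay, with a stated time of 48 h; on this read-out higher numbers stand for weaker inhibition of growth and lower numbers for stronger inhibition of growth. Among the three measured compounds this is the second highest number; compound 2 `Cc1ccccc1Nc1nc(Nc2ccc(N3CCCCC3)cn2)ncc1Cl` with 42400 nM sits within the scatter of it, while compound 1 `Cc1ccccc1Nc1nc(Nc2ccc(N3CCNCC3)cn2)ncc1Cl` with 1850 nM lies beyond the scatter below it. Going by the values given here, the only measured step, a 23-fold higher number from compound 1 to compound 2 (1.36 log units; beyond the scatter), swaps the saturated ring on the other side of the shared core and does not touch the nitrogen changed here.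

Compound 4 `COc1cccc(Nc2nc(Nc3ccc(N4CCN(C)CC4)cn3)ncc2Cl)c1` differs from compound 3 by 3-methoxyphenyl in place of 4-(trifluoromethyl)benzyl on a nitrogen on an aromatic ring. Among the compounds with values here, no measured step alters this nitrogen, so the only guide is that compounds 1 and 2, which carry an aryl group on the same nitrogen, bracket a wide span of numbers. Since compound 1 shares the aryl amine and a piperazine, a step toward its value 1850 nM is expected, though with wide uncertainty. The expected step is a 4.4-fold lower number from compound 3 to compound 4 (0.64 log units; beyond the scatter); compound 4 is estimated at 6000 nM, ranging from 1500 nM to 25000 nM.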

Compound 4, concentration for 50% growth inhibition: 3470 nM
Beside the measured number, compound 4's estimate is 1.7-fold (0.24 log units) above it, and the stated range covers the measured number.
By their numbers in this assay, from the lowest: compounds 1 and 4 (each within the scatter of the next); then compounds 3 and 2 (each within the scatter of the next).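

The group on the nitrogen on an aromatic ring now has a measured step of its own: in this assay, a 7.6-fold lower number from compound 3 to compound 4 (0.88 log units; beyond the scatter). Going by these compounds alone, the number therefore responds to this group as well as to the piperazin-1-yl to piperidin-1-yl change, where the earlier compounds gave a 23-fold higher number from compound 1 to compound 2 (1.36 log units; beyond the scatter). The new step changes the link to the ring, the ring substituent and its location all at once, so it cannot be assigned to any one of these, and no measurement available here bears on what lies behind it.

The compounds shown leave open which part of the exchange carries the step; a 3-methoxybenzyl or a 4-(trifluoromethyl)phenyl group on this nitrogen would separate them. Also open, on these data alone, is whether a step of this size would recur with piperidin-1-yl in place of the methylpiperazine.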